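Pyrazole to N-methylpyrrole exchange on the imidazoline series

This account rests on a few compounds, and the source may have more. Where it says the series, first, only, none or still open, it means among the compounds named here.

For the measured compounds named here, compound 2 `c1ccc(-c2cn[nH]c2)c(NCC2=NCCN2)c1` is the only member with a numerical reading: in an in vitro functional assay on cells (Fibroblast) for agonist activity at Alpha-1B adrenergic receptor (Homo sapiens) (on this read-out higher numbers stand for an effect only at larger amounts of compound and lower numbers for an effect already at smaller amounts), compound 2 gives 79.4 nM. Compound 1 `CCn1cc(-c2ccccc2NCC2=NCCN2)cn1` gives only a limit in this assay, < 100000 nM. Going by the values given here, the single measured step, a step that the limit leaves unreadable from compound 1 to compound 2, therefore cannot be sized, as the limit of < 100000 nM in this assay, at which 1 of the 2 values shown sits, shows. Compound 3 `Cn1cccc1-c1ccccc1NCC1=NCCN1` alters compound 2 at a different site: 1-methyl-1H-pyrrol-2-yl in place of 1H-pyrazol-4-yl on an aromatic carbon. Among the compounds with values here, no measured step touches this exchange. Within the data shown here, the one comparison available, from compound 1 to compound 2, concerns an alkyl on an aromatic nitrogen and is left unreadable by the limit, so nothing measured fixes the direction or the size of the coming step. Compound 3 is expected to come out near 1000 nM, between 100 nM and 30000 nM, the estimated step of a 13-fold higher number from compound 2 to compound 3 (1.10 log units; beyond the scatter) carrying wide uncertainty.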

Compound 3, half-maximal effective concentration: < 100000 nM
Compound 3 was reported as a limit; the forecaster's own chance of this, stated with the estimate: 25%; the middle value is on the limit's open side.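

Compound 3 gives only a limit in this assay, and the step from compound 2 to compound 3 cannot be read: the limit of < 100000 nM in this assay, at which 2 of the 3 values shown sit.

The compounds shown leave open in which direction and how far 1-methyl-1H-pyrrol-2-yl in place of 1H-pyrazol-4-yl shifts the reading in this assay.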